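Swapping the aryl ether for a fluorophenyl thioether

A few compounds are considered here, and "the series" means these few. Any claim that something is new, unique, unknown or untested is made for them only; others in the source may bear on it.

Three compounds from this study were tested in a functional assay on SNB-19 cells (Homo sapiens) for inhibition, read by sulforhodamine B assay, with a stated time of 48 h; a higher number here means a weaker inhibitor of growth, a lower number a stronger inhibitor of growth. Compound 1, with the structure `Nc1cc(N)c2nc(-c3ccccc3)c(Oc3ccc(Cl)c(Cl)c3)nc2c1`, gives 20900 nM, the lowest of the two numbers that were actually read. Compound 3, `CCOC(=O)[C@H](CCC(=O)O)NC(=O)c1ccc(Sc2nc3cc(N)cc(N)c3nc2-c2ccccc2)cc1`, gives 56200 nM, a higher number that lies beyond the usual scatter of the assay, so compound 1 is the stronger of these two. Compound 2, `CCOC(=O)[C@H](CCC(=O)O)NC(=O)c1ccc(CNc2nc3cc(N)cc(N)c3nc2-c2ccccc2)cc1`, gives < 100000 nM, which is only a limit of the assay and not a number (the limit of < 100000 nM in this assay, at which 1 of the 3 values shown sits).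

Compound 4, `Nc1cc(N)c2nc(-c3ccccc3)c(Sc3ccc(F)cc3)nc2c1`, has not yet been measured in this assay. It differs from compound 1 in one place: (4-fluorophenyl)sulfanyl in place of 3,4-dichlorophenoxy on an aromatic carbon of the shared core. Among the measured compounds shown here, no pair of measured compounds shows this exact change, so its effect cannot be read from the data. The expectation is a small loss, within or just beyond the scatter: the estimated step from compound 1 to compound 4 is a 1.5-fold higher number from compound 1 to compound 4 (0.19 log units; within the scatter). Compound 4 is thus expected to give about 32000 nM in this assay, with a likely range from 10000 nM to 95000 nM.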

Compound 4, concentration for 50% growth inhibition: 20000 nM
Beside the measured number, compound 4's estimate is 1.6-fold (0.20 log units) above it; the range from low to high includes it.
By their numbers in this assay, from the lowest: compounds 4 and 1 (each within the scatter of the next); then compound 3.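

In this assay, putting (4-fluorophenyl)sulfanyl in place of 3,4-dichlorophenoxy on this aromatic carbon of the shared core gives a 1.0-fold lower number from compound 1 to compound 4 (0.02 log units; within the scatter), so the two compounds cannot be told apart. Among the compounds shown here, until now this position carried only one measured group among compounds with this simple core; the new pair shows that the linking oxygen and both chlorines can be exchanged for a linking sulfur and a single fluorine, all in one step, with no change in the growth-inhibition reading beyond normal assay variation. Nothing in the data shown explains why these two groups read alike.

The exchange alters the linking atom and the ring substituents together, so the pair cannot show what each alteration does alone, and opposing contributions that happen to cancel cannot be separated from two alterations that each do nothing. Going by these compounds, it also remains open whether this position accepts groups of a different kind, such as a dimethylamino group or a longer alkyl chain, in place of the aryl ring, and whether any of them would give a clearly different reading.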